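This account rests on a few compounds, and the source may have more. Where it says the series, first, only, none or still open, it means among the compounds named here.

Measured compounds in a functional assay on NCI-H460 cells (Homo sapiens) for inhibition, read by MTT assay, with a stated time of 24 h, tested at 0.1 ug/mL; a higher number here means more inhibition of growth at the concentration tested, a lower number less inhibition of growth:
compound 1 `O=C(CCCCC(S)CCS)Nc1ccccc1` gives 5.5%
compound 2 `O=C(CCCCC(S)CCS)Nc1ccccc1Cl` gives 6.36%
compound 3 `O=C(CCCCC(CCSC(=O)c1ccccc1)SC(=O)c1ccccc1)Nc1ccccc1` gives 0.6%

Compound 4 `O=C(CCCCC(CCSC(=O)c1ccccc1)SC(=O)c1ccccc1)Nc1ccccc1Cl` is not yet measured.

Compound 1 and compound 2 share a core and differ by chloro in place of hydrogen on an aromatic carbon. The step in this assay is a number 0.9 percentage points higher from compound 1 to compound 2 (within the scatter), so the pair lies within the scatter of each other and no order can be set between them. Compound 3 and compound 4 differ by chloro in place of hydrogen on an aromatic carbon. The place is described in the same words for both pairs, so the change from compound 3 to compound 4 is the same change as that from compound 1 to compound 2. The difference between the core of compound 1 and the core of compound 3 is not broken down here. The value of compound 3 sits within the scatter of compound 1 and of compound 2, so these three numbers cannot be ranked.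

For compound 4 the step is expected to be a number 0.9 percentage points higher from compound 3 to compound 4 (within the scatter), set beside the earlier step, because a number 0.9 percentage points higher from compound 1 to compound 2 (within the scatter) stayed within the scatter and the change is the same. Compound 4 is therefore estimated at 1.5%, with a likely range from -8% to 11%.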

Compound 4, percent growth inhibition at one concentration: 15.1%
Estimate against measurement, compound 4: 13.6 percentage points below; measured number above the stated range.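

In this assay, chloro in place of hydrogen on the core of compound 3, that is phenyl to 2-chlorophenyl, gives a number 14.5 percentage points higher from compound 3 to compound 4 (beyond the scatter). Set beside the same change on the core of compound 1, the two steps cannot be told apart: the same change on two cores in this assay, a number 0.9 percentage points higher (within the scatter) from compound 1 to compound 2 and a number 14.5 percentage points higher (beyond the scatter) from compound 3 to compound 4, 13.6 percentage points apart, within the scatter of two such steps. For the compounds shown here, the pairs therefore do not show that the change behaves differently on the two cores, and they do not show that it carries over unchanged either, since only one of the two steps lies beyond the scatter and two pairs give no rule for any further core.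

Chloro is the only group shown on the aromatic ring, and only in one place, so it remains open whether fluoro or methoxy there would give a step of similar size in this assay. Also open, on these data alone, is how the change would behave on a core with acetyl in place of each benzoyl group, or with a longer chain between the amide carbonyl and the sulfur-bearing carbons.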